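Solubility Near the Limit Across a Shared Core

The source may report more compounds than this note shows. Statements on the series, on what has been measured and on what is new or still open speak of the compounds shown alone.

Measured so far in a physicochemical assay for solubility, read by HPLC, using the shake flask method, measured as kinetic solubility, with a stated time of 2 h, at pH 7.4; a lower number here means a less soluble compound, a higher number a more soluble compound:
compound 1 `Cc1cc(NCc2ccccn2)n2ncc(-c3ccc(N(C)C)cc3)c2n1`: < 5000 nM
compound 2 `Cc1cc(NCc2ccccn2)n2ncc(-c3ccc(C#N)cc3)c2n1`: < 5000 nM

Compound 1 `Cc1cc(NCc2ccccn2)n2ncc(-c3ccc(N(C)C)cc3)c2n1` is reported in this assay only as a limit, < 5000 nM. Compound 2 `Cc1cc(NCc2ccccn2)n2ncc(-c3ccc(C#N)cc3)c2n1` is likewise reported only as a limit, < 5000 nM. The step that the two limits leave unreadable from compound 1 to compound 2 is therefore not readable in size or direction; both values sit at the limit of < 5000 nM in this assay, at which 2 of the 2 values shown sit. For the measured compounds named here, compound 2 thus stands at the limit of this assay, and the one further value shown is a limit as well, so nothing places it relative to compound 1.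

Compound 3 `Cc1cc(NCc2ccccn2)n2ncc(-c3ccccc3C)c2n1` differs from compound 2 by 2-methylphenyl in place of 4-cyanophenyl on an aromatic carbon. Going by the values given here, only one measured step bears on this kind of change, and that step is unreadable, so no size can be carried over from it. With both measured compounds at the limit, compound 3 is expected to remain near that limit as well. Compound 3 is estimated at 2500 nM, with a range of 400 nM to 9000 nM. The expected step that the limit leaves unreadable from compound 2 to compound 3 is accordingly small, not beyond the scatter, with the outcome most likely again a limit.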

Compound 3, solubility: < 5000 nM
Compound 3 gave a limit, no number; the forecaster's own chance of this, stated with the estimate: 70%; the middle value is on the limit's open side.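

For the compounds shown here, compound 3 is reported in this assay only as a limit, < 5000 nM, so no step from compound 1 or compound 2 to compound 3 can be read in size or direction. All three compounds share one reported value: the limit of < 5000 nM in this assay, at which 3 of the 3 values shown sit.

Going by these compounds, how the solubilities of compound 1, compound 2 and compound 3 actually compare remains open.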